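From 2-hydroxyethyl to 2-methoxyethyl in compound 4

The compounds below may be only part of what the source reports. "The series", "measured", "known", "first", "only" and "open" are said of these compounds alone.

Within the data shown here, in an ADME assay on L929 cells (Mus musculus) for cytotoxicity, read by resazurin assay, with a stated time of 48 h (on this read-out lower numbers stand for higher toxicity in this test and higher numbers for lower toxicity in this test), compound 1 `O=c1c2cc([N+](=O)[O-])ccc2n(CCCBr)n1Cc1ccccc1` gives 25200 nM and is the only measured compound with a true number. Compound 2 `CN(C)C(=O)CCCn1c2ccc([N+](=O)[O-])cc2c(=O)n1Cc1ccccc1` gives > 256000 nM in the same test, which is a limit of the assay and not a number. Compound 3 `O=c1c2cc([N+](=O)[O-])ccc2n(CCO)n1Cc1ccccc1` gives > 256000 nM, again a limit and not a number. Compound 3 therefore stands at the limit of > 256000 nM in this assay, at which 2 of the 3 values shown sit, and has no readable position beyond it.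

Compound 4 `COCCn1c2ccc([N+](=O)[O-])cc2c(=O)n1Cc1ccccc1` differs from compound 3 by methyl in place of hydrogen on an oxygen on a saturated carbon, with methyl in place of hydrogen on an oxygen on a saturated carbon, so that 2-hydroxyethyl becomes 2-methoxyethyl. Among the measured compounds shown here, no measured step tests this change directly. The nearest evidence is an at least 10-fold higher number from compound 1 to compound 3 (1.00 log units; beyond the scatter) and an at least 10-fold higher number from compound 1 to compound 2 (1.00 log units; beyond the scatter), both beyond the scatter and both removing the bromo group, which compound 4 also lacks. The remaining comparison is a step that the two limits leave unreadable from compound 2 to compound 3 and adds no size. On these steps, no change beyond the scatter is expected in this assay, and a small move in either direction would go unseen if the limit is reported again. The estimated change is an at least 1.1-fold lower number from compound 3 to compound 4 (0.06 log units; that floor lies within the scatter) and is expected to stay within the scatter. Compound 4 is expected at about 220000 nM, with an estimated range from 90000 nM to 400000 nM, and the assay may well report only a limit.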

Compound 4, concentration lethal to 50% of the cells: > 256000 nM
Compound 4 ended at the assay's limit; the forecaster's own chance of this, stated with the estimate: 65%; middle value at least 1.1-fold (0.06 log units) away from the limit.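

In this assay, turning the hydroxy of compound 3 into a methoxy leaves compound 4 without a true number, and neither the step from compound 3 nor the step from compound 2 to compound 4 can be read, as both ends of each are limits. Among these compounds, the position therefore tolerates the added methyl on the oxygen only as far as this test can see, and the one step that can be read is an at least 10-fold higher number from compound 1 to compound 4 (1.00 log units; beyond the scatter). Compound 4 now gives a third compound without the bromo group, and one whose chain carries no hydroxy, that sits at the same limit of the assay: the limit of > 256000 nM in this assay, at which 3 of the 4 values shown sit.

As far as these compounds go, how far compound 2, compound 3 and compound 4 lie past that limit stays open, so any effect of the methyl on the oxygen could go unseen in this test. The compounds shown also leave open whether the true number of compound 1, 25200 nM, goes with the bromo group itself, or whether a chloro group or an amine at the end of the same chain would also bring the number down.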